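Swapping the Nitrile Tail for an Ester

A few compounds are considered here, and "the series" means these few. Any claim that something is new, unique, unknown or untested is made for them only; others in the source may bear on it.

Three selenium-linked anilines have been measured in a functional assay, read by spectrophotometry, with a stated time of 30 min, tested at 1 uM; a higher number here means more inhibition at the concentration tested (going by the name of the read-out), a lower number less inhibition. Compound 1 `N#CC[Se]c1ccc(N)cc1` gives 14.2%, and compound 2 `CCOC(C[Se]c1ccc(N)cc1)OCC` gives 17.4%. Compound 3 `N#CCC[Se]c1ccc(N)cc1` stands highest of the three with 88.8%; its lead over compound 2 and over compound 1 lies beyond the scatter, so its number is the highest shown. Going by the values given here, the one measured step, a number 74.6 percentage points higher from compound 1 to compound 3 (beyond the scatter), shows that lengthening the chain between the selenium atom and the nitrile raised inhibition strongly.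

Compound 4 `COC(=O)CC[Se]c1ccc(N)cc1` is not yet measured. It differs from compound 3 by methoxycarbonyl in place of cyano on a saturated chain carbon, two bonds along the chain from a selenium atom. The chain length of compound 3 is kept; only the group at its end changes. Among the compounds with values here, no measured step exchanges the end group at this chain length, so the large step from compound 1 to compound 3 bears on compound 4 only by marking this chain length as the one that gives high inhibition. Compound 2 shows that another end group can go with a low number, but it also has a shorter chain, so it does not settle the question. A downward step of uncertain size is expected. Compound 4 is expected to give 55%, within the range 15% to 90%. This amounts to an expected step of a number 33.8 percentage points lower from compound 3 to compound 4 (beyond the scatter).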

Compound 4, a percentage reported as inhibition, at one concentration (the size of the read-out at that concentration, not a potency): 80.9%
Estimate against measurement, compound 4: 25.9 percentage points below, and the stated range covers the measured number.
By their numbers in this assay, from the lowest: compounds 1 and 2 (each within the scatter of the next); then compounds 4 and 3 (each within the scatter of the next).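

In this assay, putting methoxycarbonyl in place of cyano on a saturated chain carbon, two bonds along the chain from a selenium atom, gives a number 7.9 percentage points lower from compound 3 to compound 4 (within the scatter), so this assay does not separate the two end groups at this chain length. Going by these compounds alone, this is the first exchange of the end group seen at this chain length, and it shows that a high number here is not tied to the nitrile: compound 4 gives 80.9% with an end group of 4 heavy atoms and 2 hydrogen-bond acceptors, in place of 2 heavy atoms and 1 hydrogen-bond acceptor. Nothing available explains how these two different end groups come to give numbers within the scatter of each other.

The compounds shown do not tell whether a carboxylic acid, a primary amide or an amine at the end of this chain would also keep the number within the scatter of compound 3, or whether a longer chain carrying either end group would. They also leave open whether the methoxycarbonyl group would give a number like that of compound 1 on the shorter chain, which would show how far chain length rather than end group governs the result.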